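A few compounds are considered here, and "the series" means these few. Any claim that something is new, unique, unknown or untested is made for them only; others in the source may bear on it.

Measured so far in an assay on CHO cells for displacement of a labelled ligand from adenosine receptor A2b (Homo sapiens), read by scintillation counting, with a stated time of 75 min; a lower number here means a stronger inhibitor, a higher number a weaker inhibitor:

Compound 1, `O=C(CCCc1ccccc1)Nc1nc2ccccc2c(=O)s1`, gives > 1000 nM, which is a limit of the assay rather than a number.
Compound 2, `O=C(CCCc1ccc(Cl)c(Cl)c1)Nc1nc2ccccc2c(=O)s1`, gives > 1000 nM, again a limit.
Compound 3, `O=C(CCc1ccccc1Br)Nc1nc2ccccc2c(=O)s1`, gives > 1000 nM, again a limit.

Within the data shown here, compound 3 therefore stands where every value so far stands: at the limit of > 1000 nM in this assay, at which 3 of the 3 values shown sit. Because all three sit at that limit, the step that the two limits leave unreadable from compound 1 to compound 2 cannot be read, and the step that the two limits leave unreadable from compound 1 to compound 3 cannot be read either. Compound 4 is `O=C(CCCc1cccc(Cl)c1)Nc1nc2ccccc2c(=O)s1`. It differs from compound 3 by 3-chlorobenzyl in place of 2-bromophenyl on a saturated chain carbon, two bonds along the chain from a carbonyl carbon. Among the measured compounds shown here, neither measured step gives a readable size for a change of this kind, so no direction can be drawn from them; the only thing the numbers show is that three variations of the group on this chain carbon have all stayed at the limit in this assay. The step from compound 3 to compound 4 is expected to be a step that the limit leaves unreadable from compound 3 to compound 4, which most likely means another limit rather than a number. Compound 4 is estimated at 3000 nM, within 800 nM to 20000 nM.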

Compound 4, inhibition constant: >= 1000 nM
Compound 4: only a limit was reported; the forecaster's own chance of this, stated with the estimate: 85%; the middle value is on the limit's open side.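

Compound 4 gives >= 1000 nM in this assay, which is a limit and not a number. Among these compounds, no step linking compound 4 to compound 1, compound 2 or compound 3 can be read. The compounds shown leave open how strong an inhibitor any of the four actually is.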